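The source may hold more compounds than are shown below. What is called first, only, known or untested is meant among the compounds shown, and "the series" means these compounds.

In an ADME assay on microsomes from liver (Homo sapiens) for metabolic stability, read by LC-MS, with a stated time of 30 min, tested at 0.1 uM (a lower number here means that less of the compound is left, a higher number that more of the compound is left), compound 2 `Fc1ccc(Nc2cc3[nH]c(-c4cccc(C(F)(F)F)c4)nc3cn2)nc1` gives 34% and stands as the lower of the two measured numbers. Within the data shown here, its only measured neighbour is compound 1 `FC(F)(F)c1cccc(-c2nc3cnc(Nc4ccccn4)cc3[nH]2)c1`, which in this assay gives 69%; the change between them is a number 35 percentage points lower from compound 1 to compound 2 (beyond the scatter). Compound 3 `N#Cc1ccc(Nc2cc3[nH]c(-c4cccc(C(F)(F)F)c4)nc3cn2)nc1` is not yet measured in this assay. It differs from compound 2 by cyano in place of fluoro on an aromatic carbon. Among the measured compounds shown here, the one measured step touches the same place in the shared core, since from compound 1 to compound 2 a fluoro entered where compound 3 now carries a cyano, and that step was large. For the measured compounds named here, no measured step, however, exchanges fluoro for cyano, so the direction of the change from compound 2 to compound 3 cannot be read from the data; the large size of the step from compound 1 to compound 2 only shows that this place moves the number strongly. Compound 3 is therefore expected to stay within the scatter of compound 2, as a number 6 percentage points higher from compound 2 to compound 3 (within the scatter), with a wide range. The estimate for compound 3 in this assay is 40%, between 15% and 70%.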

Compound 3, percent of the compound remaining: 39%
Compound 3: middle estimate off by 1 percentage points, on the high side; measured number inside the range.
By their numbers in this assay, from the lowest: compounds 2 and 3 (each within the scatter of the next); then compound 1.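

In this assay, putting 5-cyanopyridin-2-yl in place of 5-fluoropyridin-2-yl gives a number 5 percentage points higher from compound 2 to compound 3 (within the scatter), so this exchange leaves the percent remaining within the usual scatter, even though the nitrile brings in a triple bond and a hydrogen-bond acceptor that fluoro lacks. Cyano in place of hydrogen on the same aromatic carbon gives a number 30 percentage points lower from compound 1 to compound 3 (beyond the scatter), and read together with a number 35 percentage points lower from compound 1 to compound 2 (beyond the scatter) this shows that the fall from the unsubstituted compound is not tied to fluoro alone, since two different groups at this place both lie beyond the scatter from compound 1. The compounds show this link between substitution at this place and the percent remaining, but nothing at hand bears on why it arises.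

From the compounds shown here alone, whether the same holds for other groups on this carbon, such as an amine, a carboxylic acid or a methoxy group, remains open. All three compounds also carry the same trifluoromethyl group on the other side of the shared core, so whether the pattern persists when that group is exchanged for another, such as a chloro group, is open as well.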